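The source may report more compounds than this note shows. Statements on the series, on what has been measured and on what is new or still open speak of the compounds shown alone.

Measured in a functional assay on HT-29 cells (Homo sapiens) for cytotoxicity, read by MTT assay, with a stated time of 48 h; on this read-out higher numbers stand for weaker inhibition and lower numbers for stronger inhibition:

Compound 1, `COc1ccc(CN2C(=O)C(=O)c3cc(/C=C/C(=O)OC(C)(C)C)ccc32)cc1`: 480 nM
Compound 2, `COc1ccc(CN2C(=O)C(=O)c3cc(/C=C/C(=O)OCCO)ccc32)cc1`: 550 nM
Compound 3, `COC(=O)/C=C/c1ccc2c(c1)C(=O)C(=O)N2Cc1ccc(Cl)c(Cl)c1`: 210 nM

Compound 3 gives the lowest of the three numbers; compound 1 lies beyond the scatter above it, and compound 2 further still. Compound 4, `COC(=O)/C=C/c1ccc2c(c1)C(=O)C(=O)N2Cc1ccc(OC)cc1`, differs from compound 3 by 4-methoxyphenyl in place of 3,4-dichlorophenyl on a saturated chain carbon bound to an amide-type nitrogen in a ring. Among the compounds with values here, the one measured step, a 1.1-fold higher number from compound 1 to compound 2 (0.06 log units; within the scatter), concerns the ester and does not bear on this exchange, and no measured pair differs in this group alone. Compounds 1 and 2 carry 4-methoxyphenyl but also another ester than compound 3, so their values only suggest where compound 4 might fall. Compound 4 is therefore expected to give a higher number, a 1.9-fold higher number from compound 3 to compound 4 (0.28 log units; within the scatter), with an estimate of 400 nM and a range from 200 nM to 900 nM.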

Compound 4, half-maximal inhibitory concentration: 30 nM
For compound 4 the middle estimate is 13-fold (1.12 log units) above the measured one; measured number outside the range, below it.
By their numbers in this assay, from the lowest: compound 4; then compound 3; then compounds 1 and 2 (each within the scatter of the next).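

In this assay, the group on a saturated chain carbon bound to an amide-type nitrogen in a ring clearly moves the number, since 4-methoxyphenyl in place of 3,4-dichlorophenyl gives a modest drop (a 7.0-fold lower number from compound 3 to compound 4 (0.85 log units; beyond the scatter)). The ester, which made no difference beyond the scatter between tert-butyl and 2-hydroxyethyl, also matters once methyl sits on the oxygen, with large drops (a 16-fold lower number from compound 1 to compound 4 (1.20 log units; beyond the scatter); an 18-fold lower number from compound 2 to compound 4 (1.26 log units; beyond the scatter)). No measurement given here accounts for either change.

Going by these compounds, what remains open is how a plain phenyl would read on that carbon, or a carboxylic acid in place of the ester.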